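This account rests on a few compounds, and the source may have more. Where it says the series, first, only, none or still open, it means among the compounds named here.

Measured compounds:
Compound 1, `CC[C@H](CCn1cncn1)c1ccc(C)cc1`: 85.2 ug/mL
Compound 2, `CCC[C@H](CCn1cncn1)c1ccc(C)cc1`: 47.2 ug/mL
Compound 3, `CCCC[C@H](CCn1cncn1)c1ccc(OC)cc1`: 28.3 ug/mL

In an ADME assay on RD cells (Homo sapiens) for cytotoxicity, read by MTT assay, with a stated time of 3 days (on this read-out higher numbers stand for lower toxicity in this test and lower numbers for higher toxicity in this test), compound 3 gives the lowest of the three numbers, yet it sits within the scatter of compound 2 and only beyond the scatter of compound 1. Among the compounds with values here, the one step available between measured compounds, a 1.8-fold lower number from compound 1 to compound 2 (0.26 log units; within the scatter), concerns the saturated chain and not the aromatic ring, so it does not speak directly to the change at hand.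

Compound 4, `CCCC[C@H](CCn1cncn1)c1ccc(C)cc1`, differs from compound 3 in one place: methyl in place of methoxy on an aromatic carbon. Within the data shown here, no measured pair shows this change on its own; compounds 1 and 2, which carry the methyl, and compound 3, which carries the methoxy, also differ in chain length, so their values cannot be separated into the two effects. Given that the only measured step lies within the scatter and that nothing points one way for this change, no step beyond the scatter is expected, and the estimated step is a 1.2-fold higher number from compound 3 to compound 4 (0.09 log units; within the scatter). Compound 4 is therefore expected to give about 35 ug/mL in this assay, in a range from 17 ug/mL to 75 ug/mL.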

Compound 4, half-maximal cytotoxic concentration: 26.5 ug/mL
The estimate for compound 4 lay 1.3-fold (0.12 log units) above the measured number, within the range that was stated.
By their numbers in this assay, from the lowest: compounds 4, 3, 2 and 1 (each within the scatter of the next, the first and the last beyond it).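

In this assay, methyl and methoxy on this aromatic carbon, para to a large group, cannot be told apart: the swap gives a 1.1-fold lower number from compound 3 to compound 4 (0.03 log units; within the scatter). Within the data shown here, on the chain, one more methyl gives a 1.8-fold lower number from compound 2 to compound 4 (0.25 log units; within the scatter), yet ethyl in place of hydrogen gives a 3.2-fold lower number from compound 1 to compound 4 (0.51 log units; beyond the scatter), the only step here beyond the scatter, so two chain extensions that are each too small to read alone add up to a visible change across compounds 1, 2 and 4. Nothing available explains the cause of these differences.

Open still is whether a quite different group on the aromatic carbon, such as an amine or a carboxylic acid, would shift the number. Also open, as far as these compounds go, is whether a longer chain than that of compound 4 would continue the same trend.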